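Bromo in place of hydrogen on the methoxyphenyl amide

The source may hold more compounds than are shown below. What is called first, only, known or untested is meant among the compounds shown, and "the series" means these compounds.

Measured compounds:
Compound 1 `COc1c(Br)cccc1C(=O)Nc1ccc(Sc2nc3ccccc3s2)c(Cl)c1`. In an assay on isolated protein for inhibition of thiosulfate sulfurtransferase (Homo sapiens), with a stated time of 60 min, in the absence of a further agent (a higher number here means a weaker inhibitor, a lower number a stronger inhibitor), compound 1 gives > 100000 nM, a limit of the assay rather than a number.
Compound 2 `O=C(Nc1ccc(Sc2nc3ccccc3s2)cc1)c1cc(Br)ccc1O`. In this assay compound 2 gives > 100000 nM, again a limit.
Compound 3 `COc1ccccc1C(=O)Nc1ccc(Sc2nc3ccccc3s2)cc1`. In this assay compound 3 gives > 100000 nM, also a limit.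

Compound 3 therefore stands at the limit and nowhere else: no number is known for it, and the same holds for the other two values, which sit at the limit of > 100000 nM in this assay, at which 3 of the 3 values shown sit. Among the measured compounds shown here, the one step between compounds that differ in a single place, a step that the two limits leave unreadable from compound 2 to compound 3, is unreadable for that reason.

Compound 4 `COc1c(Br)cccc1C(=O)Nc1ccc(Sc2nc3ccccc3s2)cc1` differs from compound 3 as follows: bromo in place of hydrogen on an aromatic carbon. For the measured compounds named here, no measured step bears directly on this change. Compound 1 also carries a bromo group and a methoxy group, and its value is a limit. With every value at the limit, no direction can be read from the data, and no step beyond the scatter is expected.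

The step of a number no higher from compound 3 to compound 4 (the limit leaves the size open) is expected to be flat. Compound 4 is expected at 100000 nM, with a range from 30000 nM to 300000 nM, and most likely only a limit will again be reported.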

Compound 4, half-maximal inhibitory concentration: > 100000 nM
Compound 4: only a limit was reported; the forecaster's own chance of this, stated with the estimate: 85%; the middle value lies on the limit itself.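

No new step can be read between compound 4 and compound 1, compound 2 or compound 3, because each value is a limit and not a number: the limit of > 100000 nM in this assay, at which 4 of the 4 values shown sit.

The compounds shown leave open what number any of them would give in this assay and whether any change among them alters inhibition at all.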